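Swapping Bromine for a Fluorinated Pyridine: Clearance Outlook

A few compounds are considered here, and "the series" means these few. Any claim that something is new, unique, unknown or untested is made for them only; others in the source may bear on it.

Measured compounds in an ADME assay (liver) for metabolic stability, with Liver microsome (Homo sapiens) as the target, using microsomes and NADPH, with a stated time of 30 min, tested at 1 uM; on this read-out lower numbers stand for slow clearance and higher numbers for fast clearance:
- compound 1, `Nc1ccc(S(=O)(=O)N2CCN(c3ncc(C(O)(C(F)(F)F)C(F)(F)F)cc3Br)CC2)cn1`, reported only as a limit: < 14 mL.min-1.g-1
- compound 2, `Nc1ccc(S(=O)(=O)N2CCN(c3ncc(C(O)(C(F)(F)F)C(F)(F)F)cc3-c3ccccc3O)CC2)cn1`: 22 mL.min-1.g-1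
- compound 3, `Nc1ccc(S(=O)(=O)N2CCN(c3ncc(C(O)(C(F)(F)F)C(F)(F)F)cc3-c3ccncc3)CC2)cn1`: 15 mL.min-1.g-1

Compound 1 has no exact number in this assay; it sits at the limit of < 14 mL.min-1.g-1 in this assay, at which 1 of the 3 values shown sits, so its true clearance could lie anywhere under that floor. Compounds 2 and 3 replace the bromo of the shared core with an aromatic group and each gave a measured number. The steps were an at least 1.5-fold higher number from compound 1 to compound 2 (0.19 log units; that floor lies within the scatter) and an at least 1.0-fold higher number from compound 1 to compound 3 (0.02 log units; that floor lies within the scatter). Between the two aromatic replacements the gap is a 1.5-fold lower number from compound 2 to compound 3 (0.17 log units; within the scatter), so the three compounds are not separated by more than the usual spread of the method.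

Compound 4, `Nc1ccc(S(=O)(=O)N2CCN(c3ncc(C(O)(C(F)(F)F)C(F)(F)F)cc3-c3cnccc3F)CC2)cn1`, differs from compound 1 in a single place: 4-fluoropyridin-3-yl in place of bromo on an aromatic carbon. The two measured steps that bear on it are the aromatic replacements in compounds 2 and 3, both of which produced numbers just above the floor of compound 1. The same modest rise, if any, is expected for compound 4, an at least 1.2-fold higher number from compound 1 to compound 4 (0.10 log units; that floor lies within the scatter), with no clear movement beyond the scatter. Compound 4 is therefore estimated to give about 18 mL.min-1.g-1, within a range from 9 mL.min-1.g-1 to 36 mL.min-1.g-1.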

Compound 4, intrinsic clearance in microsomes: 17 mL.min-1.g-1
For compound 4 the middle estimate is 1.1-fold (0.02 log units) above the measured one, and the stated range covers the measured number.
By their numbers in this assay, from the lowest: compounds 3, 4 and 2 (each within the scatter of the next). At a limit, below all of these: compound 1.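

In this assay, 4-fluoropyridin-3-yl is a third aromatic ring at this position, and it does not stand apart from the other two: the gaps are a 1.1-fold higher number from compound 3 to compound 4 (0.05 log units; within the scatter) and a 1.3-fold lower number from compound 2 to compound 4 (0.11 log units; within the scatter). Set against bromo, a single atom replaced by a ring of seven heavy atoms with its fluorine, the step is an at least 1.2-fold higher number from compound 1 to compound 4 (0.08 log units; that floor lies within the scatter), so even this larger change shows no clear rise in clearance, and across the three ring-bearing compounds a hydroxyl on a phenyl ring, a pyridine and a fluorinated pyridine all give numbers that the method cannot tell apart. Compound 1 stands only at a limit: the limit of < 14 mL.min-1.g-1 in this assay, at which 1 of the 4 values shown sits.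

From the compounds shown here alone, how far the true number of compound 1 lies under that limit stays open, and so does any real cost of the added ring, since every step here rests on that limit or lies within the scatter. Also open, going by these compounds, are the part played by the fluorine, which a plain pyridin-3-yl group would isolate, and whether a non-aromatic group at this position, such as an amine or a carboxylic acid, would move clearance beyond the scatter.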